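The source may report more compounds than this note shows. Statements on the series, on what has been measured and on what is new or still open speak of the compounds shown alone.

Of the compounds shown here, three of this set have been measured in an ADME assay on microsomes from liver (Homo sapiens) for metabolic stability, with a stated time of 0.5 h, tested at 0.5 mg/mL; a lower number here means that less of the compound is left, a higher number that more of the compound is left. Compound 1 `CN(C)C(=O)CNC(=O)c1cc(-c2ccc(F)cc2)no1` gives 84% in this assay. Compound 3 `CC(=O)N1CC2(CC(NC(=O)c3cc(-c4ccc(F)cc4)no3)C2)C1`, which carries a different amide partner on the shared core, gives 84% in this assay. Compound 2 `CN(C)C(=O)CCNC(=O)c1cc(-c2cccc(F)c2)no1` is placed differently: in this assay compound 2 gives > 100%, which is a limit of the assay and not a number, so that where compound 2 stands among the values shown is known only as that limit (the limit of > 100% in this assay, at which 1 of the 3 values shown sits). Compound 4 `CN(C)C(=O)CCNC(=O)c1cc(-c2ccccc2)no1` has not yet been measured. It differs from compound 2 by hydrogen in place of fluoro on an aromatic carbon. Among the measured compounds shown here, no step between two measured compounds shows how such a change plays out in this assay, so the writer expects a step in this assay no larger than the usual scatter, with no clear direction. For compound 4 the expected value in this assay is 92%, in the range from 75% to 100%. The estimated step of a number at least 8 percentage points lower from compound 2 to compound 4 (that floor lies within the scatter) is therefore expected to be small.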

Compound 4, percent of the compound remaining: 81%
Compound 4: middle estimate off by 11 percentage points, on the high side, within the range that was stated.
By their numbers in this assay, from the lowest: compounds 4, 1 and 3 (each within the scatter of the next). At a limit, above all of these: compound 2.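

In this assay, among the compounds shown here, the change from 3-fluorophenyl to phenyl gives a number at least 19 percentage points lower from compound 2 to compound 4 (beyond the scatter) and is the first step in this set between two measured compounds that differ in one place. Hydrogen in place of fluoro, on this aromatic carbon meta to a large group, thus moves the read-out beyond the scatter, which none of the earlier compounds could show. The size of that step remains only a floor, since compound 2 stands at a limit of the assay and not at a number: the limit of > 100% in this assay, at which 1 of the 4 values shown sits.

The compounds shown leave open whether the same change gives a step of this kind with another amide partner, such as that of compound 3. They also leave open whether a chloro or a methoxy group at this place would leave as much compound remaining as fluoro does.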